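Moving the methoxy group: from compound 2 to compound 4

The source may hold more compounds than are shown below. What is called first, only, known or untested is meant among the compounds shown, and "the series" means these compounds.

Of the compounds shown here, three sharing one core have been tested in a functional assay on NCI-H226 cells (Homo sapiens) for inhibition, read by sulforhodamine B assay, with a stated time of 48 h, tested at 10 uM; a higher number here means more inhibition at the concentration tested (going by the name of the read-out), a lower number less inhibition. Compound 1 `COc1ccc(-c2cn3ccnc3c(-c3ccc4ncn(C5CCCCC5)c4c3)n2)cc1` gives 35.9%, compound 2 `O=Cc1ccc(-c2cn3ccnc3c(-c3ccc4ncn(C5CCCCC5)c4c3)n2)cc1` gives 0.53%, and compound 3 `Brc1ccc(-c2cn3ccnc3c(-c3ccc4ncn(C5CCCCC5)c4c3)n2)cc1` gives 23.3%. The change was a number 35.4 percentage points lower from compound 1 to compound 2 (beyond the scatter), while a number 12.6 percentage points lower from compound 1 to compound 3 (beyond the scatter) and a number 22.8 percentage points higher from compound 2 to compound 3 (beyond the scatter). Compound 2 thus has the lowest number of the three, with compound 3 nearest and compound 1 furthest from it, both differences beyond the scatter.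

Compound 4 `COc1ccccc1-c1cn2ccnc2c(-c2ccc3ncn(C4CCCCC4)c3c2)n1` has not yet been measured in this assay. Its difference from compound 2 is 2-methoxyphenyl in place of 4-formylphenyl on an aromatic carbon. Among the compounds with values here, the step that bears most directly on this is the one from compound 1 to compound 2, where the formyl group replaced a methoxy group and the number fell by a large amount. Within the data shown here, the change to compound 4 runs that exchange in reverse, but the methoxy group now sits in the 2-methoxyphenyl rather than in the 4-methoxyphenyl of compound 1, so no measured pair tells how much of the loss is recovered. A rise beyond the scatter is therefore expected, and the step from compound 2 to compound 4 in this assay is estimated as a number 23.5 percentage points higher from compound 2 to compound 4 (beyond the scatter), though smaller than a full return to the number of compound 1. Compound 4 is expected to give 24% in this assay, within a range from 6% to 48%.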

Compound 4, a percentage reported as inhibition, at one concentration (the size of the read-out at that concentration, not a potency): 25.7%
Compound 4: middle estimate off by 1.7 percentage points, on the low side, and the stated range covers the measured number.
By their numbers in this assay, from the lowest: compound 2; then compounds 3 and 4 (each within the scatter of the next); then compound 1.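

Within the data shown here, with the 2-methoxyphenyl group in place of the 4-formylphenyl group, this assay gives a number 25.2 percentage points higher from compound 2 to compound 4 (beyond the scatter) and shows that a methoxy group placed differently from the one in compound 1 still lifts the number well clear of the near-zero reading of compound 2. Among these compounds, the placement of the methoxy group on the phenyl ring can now be read for the first time: there is a number 10.2 percentage points lower from compound 1 to compound 4 (beyond the scatter) and so a modest cost, with most of the number of compound 1 retained. The 2-methoxyphenyl and 4-bromophenyl groups cannot be told apart here, with a number 2.4 percentage points higher from compound 3 to compound 4 (within the scatter) in the same assay, which leaves compound 1 alone with the highest number of the four. Nothing at hand explains any of these steps.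

The compounds shown leave open whether a hydroxyl group, an amine or a carboxylic acid on the phenyl ring would reach or pass the number of compound 1. From the compounds shown here alone, it also stays open whether another carbonyl group, such as an amide or an ester, would fall as low as compound 2 does.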